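This account rests on a few compounds, and the source may have more. Where it says the series, first, only, none or still open, it means among the compounds named here.

Values in an ADME assay on HepG2 2.2.15 cells (Homo sapiens) for cytotoxicity; a higher number here means that more compound is tolerated, a lower number that less compound is tolerated:
compound 1 `O=C(CN1C(=O)c2ccccc2C1=O)OCCc1c(-c2ccccc2Cl)c2cc(Cl)ccc2[nH]c1=O`: 960000 nM
compound 2 `COc1ccc(/C=C/C(=O)OCCc2c(-c3ccccc3Cl)c3cc(Cl)ccc3[nH]c2=O)cc1OC`: > 1200000 nM, a limit and not a number

Compound 2 has no exact number and stands only at the limit of > 1200000 nM in this assay, at which 1 of the 2 values shown sits. Compound 3 `C/C=C/C=C/C(=O)OCCc1c(-c2ccccc2Cl)c2cc(Cl)ccc2[nH]c1=O` carries prop-1-en-1-yl in place of 3,4-dimethoxyphenyl on a double-bonded chain carbon bound to a double-bonded chain carbon. Among the measured compounds shown here, the one measured step, an at least 1.2-fold higher number from compound 1 to compound 2 (0.09 log units; that floor lies within the scatter), also exchanges a group in this part of the structure, on a carbonyl carbon. The expected change is an at least 1.0-fold lower number from compound 2 to compound 3 (0.03 log units; that floor lies within the scatter), with no shift expected beyond the scatter. For compound 3 the estimate is 1100000 nM, with an expected range of 600000 nM to 2000000 nM.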

Compound 3, half-maximal cytotoxic concentration: 440000 nM
Compound 3: middle estimate off by 2.5-fold (0.40 log units), on the high side, outside the stated range (below it).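

In this assay, prop-1-en-1-yl in place of 3,4-dimethoxyphenyl gives the first shift in this series beyond the scatter: an at least 2.7-fold lower number from compound 2 to compound 3 (0.43 log units; beyond the scatter). Compound 2 has a limit and not a number, so that step gives only a floor: the limit of > 1200000 nM in this assay, at which 1 of the 3 values shown sits. On the carbonyl carbon, the exchange from compound 1 also goes beyond the scatter, with a 2.2-fold lower number from compound 1 to compound 3 (0.34 log units; beyond the scatter), so the tolerated concentration does respond to the group at this place.

From the compounds shown here alone, whether the drop follows the double bonds or the loss of the ring remains open. A saturated pentyl chain on the same carbonyl carbon would separate the two, and an amine or a carboxylic acid at this place is also untested here.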